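Cyclopentyl to 1-methylcyclopropyl in the series

The compounds below may be only part of what the source reports. "The series", "measured", "known", "first", "only" and "open" are said of these compounds alone.

Of the compounds shown here, two have numbers so far. In a physicochemical assay for solubility, using the shake flask method, measured as kinetic solubility, with a stated time of 20 h, at pH 2 (on this read-out lower numbers stand for lower solubility and higher numbers for higher solubility), compound 1 (`FC(F)(F)c1cccc(-c2nc3cnc(Nc4ccccn4)cc3[nH]2)c1`) gives 21000 nM. Compound 2 (`FC(F)(F)c1ccc(Nc2cc3[nH]c(C4CCCC4)nc3cn2)nc1`) gives 132000 nM in this assay, the higher of the two numbers, and the gap between them lies beyond the scatter. Within the data shown here, these two compounds differ in more than one place, so they offer no step for a single change.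

Next in line is compound 3 (`CC1(c2nc3cnc(Nc4ccc(C(F)(F)F)cn4)cc3[nH]2)CC1`), which carries 1-methylcyclopropyl in place of cyclopentyl on an aromatic carbon, between two ring nitrogen atoms: 1-methylcyclopropyl in place of cyclopentyl on an aromatic carbon. The rest of the structure stays as in compound 2. Among the measured compounds shown here, no measured pair covers this exchange, so the expectation rests on compound 2 at 132000 nM alone, and the range has to stay wide. In this assay only a small upward step is expected, one that stays inside the scatter: the estimated change is a 1.3-fold higher number from compound 2 to compound 3 (0.11 log units; within the scatter). For compound 3 the estimated value is 170000 nM, with an expected range of 60000 nM to 400000 nM.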

Compound 3, solubility: 200000 nM
Estimate against measurement, compound 3: 1.2-fold (0.07 log units) below, within the range that was stated.
By their numbers in this assay, from the lowest: compound 1; then compounds 2 and 3 (each within the scatter of the next).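

In this assay, the exchange of cyclopentyl for 1-methylcyclopropyl on this aromatic carbon, between two ring nitrogen atoms, gives a 1.5-fold higher number from compound 2 to compound 3 (0.18 log units; within the scatter), so this first single-change step at the position shows no readable effect on the number. The ring on this carbon goes from five-membered to three-membered, and the read-out does not separate compound 2 from compound 3, which means this pair gives no basis for preferring either group in this assay. Among these compounds, both groups are non-aromatic, carbon-only rings with no hydrogen-bond donors or acceptors and no net charge, so the step speaks only to an exchange within that narrow kind of group, and compound 1 stays outside the reading, with no single-change step linking it to compound 2 or compound 3.

Still open, from the compounds shown here alone, is whether an amine, a carboxylic acid or a longer chain on this same carbon would give a step beyond the scatter, and whether the same exchange would read the same way on a different core. Nothing at hand gives a measured property that accounts for this result.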